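Methoxy on the fused ring of a quinolinone-type permeability series

This account rests on a few compounds, and the source may have more. Where it says the series, first, only, none or still open, it means among the compounds named here.

Measured so far in an ADME assay for permeability, using PAMPA, at pH 4; on this read-out lower numbers stand for lower permeability and higher numbers for higher permeability:
- compound 1 `Cc1[nH]c2ccccc2c(=O)c1Cc1ccccc1` gives 110 10^-6 cm/s
- compound 2 `CCCCC#Cc1c(C)[nH]c2ccc(OC)cc2c1=O` gives 1020 10^-6 cm/s
- compound 3 `CCCCC#Cc1c(C)[nH]c2ccccc2c1=O` gives 500 10^-6 cm/s

Within this assay the one single-point step is a 2.0-fold higher number from compound 3 to compound 2 (0.31 log units; beyond the scatter), the change being (methoxy in place of hydrogen on an aromatic carbon). Compound 1 stands lowest of the three; how its core differs from that of compound 3 is not broken down here.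

Compound 4 `COc1cccc2c(=O)c(Cc3ccccc3)c(C)[nH]c12` is not yet measured. It differs from compound 1 by methoxy in place of hydrogen on an aromatic carbon. This is the same kind of change as from compound 3 to compound 2, but not the same: in compound 2 the methoxy sits meta and para to a fused ring, in compound 4 ortho and meta to a fused ring. Resting on the step from compound 3 to compound 2, a step of a 2.0-fold higher number from compound 1 to compound 4 (0.30 log units; within the scatter) is expected, with a wider range because the placement differs. Compound 4 is therefore estimated at 220 10^-6 cm/s, between 110 10^-6 cm/s and 450 10^-6 cm/s.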

Compound 4, apparent permeability: 164 10^-6 cm/s
Beside the measured number, compound 4's estimate is 1.3-fold (0.13 log units) above it, and the stated range covers the measured number.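

In this assay methoxy in place of hydrogen gives a 1.5-fold higher number from compound 1 to compound 4 (0.17 log units; within the scatter) and stays in the same range as the earlier step on the other core: the same change on two cores in this assay, a 2.0-fold higher number (0.31 log units; beyond the scatter) from compound 3 to compound 2 and a 1.5-fold higher number (0.17 log units; within the scatter) from compound 1 to compound 4, 1.4-fold (0.14 log units) apart, within the scatter of two such steps. The change therefore carries across these two cores to within what this read-out can resolve. Within the data shown here, this does not establish a general rule for the series: there are only two steps, and they differ in both core and methoxy placement, so those two factors cannot be separated.

Open, on these data alone, is how methoxy behaves when only its placement changes on a single core. Also open, as far as these compounds go, is whether an amine or a carboxylic acid on the same aromatic carbon would follow the methoxy steps.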